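This account rests on a few compounds, and the source may have more. Where it says the series, first, only, none or still open, it means among the compounds named here.

In a functional assay on A549 cells (Homo sapiens) for antiproliferative activity, read by sulforhodamine B assay, with a stated time of 48 h (a higher number here means a weaker inhibitor, a lower number a stronger inhibitor), compound 1 `COc1cccc(/C=C/C(=O)/C=C(O)/C=C/c2cccc(OC)c2OC)c1OC` gives 11500 nM, compound 2 `COc1cc(OC)c(/C=C/C(=O)C(=Cc2ccc(O)c(OC)c2)C(=O)/C=C/c2c(OC)cc(OC)cc2OC)c(OC)c1` gives 580 nM and compound 3 `COc1cc(OC)c(/C=C/C(=O)C(=Cc2ccc(O)c(F)c2)C(=O)/C=C/c2c(OC)cc(OC)cc2OC)c(OC)c1` gives 1060 nM. Compound 3 therefore stands within the scatter of compound 2 and well below compound 1. Compound 4 `COc1cc(OC)c(/C=C/C(=O)C(=Cc2cc(Br)c(O)c(OC)c2)C(=O)/C=C/c2c(OC)cc(OC)cc2OC)c(OC)c1` differs from compound 3 as follows: 3-bromo-4-hydroxy-5-methoxyphenyl in place of 3-fluoro-4-hydroxyphenyl on a double-bonded chain carbon bound to a double-bonded chain carbon. Within the data shown here, the only measured step on this same phenyl group is a 1.8-fold higher number from compound 2 to compound 3 (0.26 log units; within the scatter), and it stays within the scatter. Among the measured compounds shown here, no bromo compound has been measured yet, so no step beyond the scatter is expected in this assay. The estimated step is a 1.4-fold lower number from compound 3 to compound 4 (0.15 log units; within the scatter). For compound 4 the expected value is 750 nM, with an estimated range of 280 nM to 2000 nM.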

Compound 4, half-maximal inhibitory concentration: 730 nM
Beside the measured number, compound 4's estimate is 1.0-fold (0.01 log units) above it, within the range that was stated.
By their numbers in this assay, from the lowest: compounds 2, 4 and 3 (each within the scatter of the next); then compound 1.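

In this assay the 3-bromo-4-hydroxy-5-methoxyphenyl group on a double-bonded chain carbon bound to a double-bonded chain carbon is tolerated, with a 1.5-fold lower number from compound 3 to compound 4 (0.16 log units; within the scatter) and a 1.3-fold higher number from compound 2 to compound 4 (0.10 log units; within the scatter). Bromo in place of hydrogen on an aromatic carbon thus joins fluoro in place of methoxy as a second change on this phenyl group that stays within the scatter. No measurement available here explains these steps.

From the compounds shown here alone, whether an amine or a carboxylic acid in place of the bromo would give a step beyond the scatter remains open. So does whether any change on this phenyl group would.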